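Azetidine substitution on the pyridyl ring of a thiazole acid

The compounds below may be only part of what the source reports. "The series", "measured", "known", "first", "only" and "open" are said of these compounds alone.

The compounds measured so far:
Compound 1 `O=C(O)Cc1sc(C(c2ccc(F)cc2)c2ccc(F)cc2)nc1-c1ccco1` — 140 nM
Compound 2 `O=C(O)Cc1sc(C(c2ccc(F)cc2)c2ccc(F)cc2)nc1-c1cn[nH]c1` — 220 nM
Compound 3 `O=C(O)Cc1sc(C(c2ccc(F)cc2)c2ccc(F)cc2)nc1-c1ccncc1` — 40 nM

In an in vitro functional assay on HEK285-7 cells for antagonist activity at prostaglandin D2 receptor 2 (Homo sapiens), read by BRET and beta-arrestin recruitment (on this read-out lower numbers stand for stronger inhibition and higher numbers for weaker inhibition), compound 3 gives the lowest number of the three. The step of a 3.5-fold lower number from compound 1 to compound 3 (0.54 log units; beyond the scatter) and the step of a 5.5-fold lower number from compound 2 to compound 3 (0.74 log units; beyond the scatter) both lie beyond the scatter, so compound 3 is the most potent of the measured set, while compound 1 and compound 2 are separated only by a 1.6-fold higher number from compound 1 to compound 2 (0.20 log units; within the scatter), which stays within the scatter.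

Compound 4 `O=C(O)Cc1sc(C(c2ccc(F)cc2)c2ccc(F)cc2)nc1-c1ccnc(N2CCC2)c1` keeps the core of compound 3 and differs from it by azetidin-1-yl in place of hydrogen on an aromatic carbon. Among the measured compounds shown here, no measured step touches this kind of change: the two steps beyond the scatter, a 3.5-fold lower number from compound 1 to compound 3 (0.54 log units; beyond the scatter) and a 5.5-fold lower number from compound 2 to compound 3 (0.74 log units; beyond the scatter), each exchange the whole aromatic ring rather than adding a group to the pyridin-4-yl ring of compound 3. For the measured compounds named here, the account therefore has no direct precedent, and the expectation is a step of about no change at the digits printed from compound 3 to compound 4 (within the scatter), that is, no clear movement beyond the scatter. For compound 4 the estimate in this assay is 40 nM, with a range from 12 nM to 130 nM.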

Compound 4, half-maximal inhibitory concentration: > 100000 nM
Compound 4 gave a limit, no number; the forecaster's own chance of this, stated with the estimate: 3%; middle value at least 2500-fold (3.39 log units) from the limit.
By their numbers in this assay, from the lowest: compound 3; then compounds 1 and 2 (each within the scatter of the next). At a limit, above all of these: compound 4.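

In this assay compound 4 stands at > 100000 nM, which is a limit of the assay and not a number. The earlier steps shown here exchanged the whole aromatic ring, whereas azetidin-1-yl in place of hydrogen, next to the ring nitrogen, gives an at least 2500-fold higher number from compound 3 to compound 4 (3.39 log units; beyond the scatter); against the other two rings the steps are an at least 450-fold higher number from compound 2 to compound 4 (2.65 log units; beyond the scatter) and an at least 710-fold higher number from compound 1 to compound 4 (2.85 log units; beyond the scatter). A single added group on the pyridin-4-yl ring can therefore matter far more here than any change of ring among the earlier compounds, and the true size of the step remains unknown past the limit: the limit of > 100000 nM in this assay, at which 1 of the 4 values shown sits.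

The compounds shown leave open whether this loss belongs to azetidin-1-yl itself or to any group on this carbon. A methyl group, a fluorine atom or an open-chain dimethylamine on the same carbon would separate these two readings.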